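Hydroxy on the core of compound 1

The source may hold more compounds than are shown below. What is called first, only, known or untested is meant among the compounds shown, and "the series" means these compounds.

Among the compounds with values here, in a functional assay on DU-145 cells (Homo sapiens) for inhibition, read by MTT assay, with a stated time of 72 h (a higher number here means a weaker inhibitor, a lower number a stronger inhibitor), compound 1 `O=C1C=C(N2CCN(c3ccc(F)cc3)CC2)C(=O)c2ccccc21` stands at 11700 nM as the higher of the two numbers so far, and compound 2 `O=C1C=C(N2CCN(c3ccccc3Cl)CC2)C(=O)c2ccccc21` stands at 2900 nM on the same scale. Compound 3 `O=C1C(N2CCN(c3ccc(F)cc3)CC2)=CC(=O)c2c(O)cccc21` differs from compound 1 by hydroxy in place of hydrogen on an aromatic carbon in the shared core, with hydroxy in place of hydrogen on an aromatic carbon. Within the data shown here, the only measured step is a 4.0-fold lower number from compound 1 to compound 2 (0.61 log units; beyond the scatter) and it concerns the group on the amine nitrogen, not the core. Among the measured compounds shown here, no measured compound carries the hydroxy group, so that step gives a rough size for a single change but no direction for this one. For the measured compounds named here, with compound 1 at the top of the numbers so far, a modest fall is expected, though a rise is not excluded. The estimated change is a 2.0-fold lower number from compound 1 to compound 3 (0.29 log units; within the scatter) in this assay as a working expectation. For compound 3 the expected value is 6000 nM with an estimated range from 1800 nM to 18000 nM in this series.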

Compound 3, half-maximal inhibitory concentration: 22400 nM
Estimate against measurement, compound 3: 3.7-fold (0.57 log units) below; the measured number lies above the stated range.
By their numbers in this assay, from the lowest: compound 2; then compounds 1 and 3 (each within the scatter of the next).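

In this assay the hydroxy group on an aromatic carbon of the shared core, ortho to a fused ring and meta to a fused ring, gives a 1.9-fold higher number from compound 1 to compound 3 (0.28 log units; within the scatter) and so leaves the reading of the 4-fluorophenyl compound inside the usual scatter. Within the data shown here, on this one pair, the core carbon offers no measurable gain, and the only step beyond the scatter remains the change on the amine nitrogen, a 4.0-fold lower number from compound 1 to compound 2 (0.61 log units; beyond the scatter). No supporting data are available to explain the hydroxy result.

One hydroxy comparison cannot show whether a methoxy group or an amine on the same aromatic carbon would read differently. As far as these compounds go, it also remains open whether hydroxy has a similar effect when the amine nitrogen carries 2-chlorophenyl rather than 4-fluorophenyl.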